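Changing the group on oxygen: compound 3 to compound 4

The compounds below may be only part of what the source reports. "The series", "measured", "known", "first", "only" and "open" are said of these compounds alone.

In a functional assay on NCI-N87 cells (Homo sapiens) for inhibition, read by CellTiter-Glo, with a stated time of 72 h (on this read-out lower numbers stand for stronger inhibition and higher numbers for weaker inhibition), three compounds with a shared core differ only in the group on the oxygen. Compound 1 `Cc1cc(Nc2ncnc3cc(O)c(NC(=O)/C=C/[C@H]4CCCN4C)cc23)ccc1Oc1cnc2ccnn2c1` gives 1.9 nM, compound 2 `Cc1cc(Nc2ncnc3cc(O)c(NC(=O)/C=C/[C@H]4CCCN4C)cc23)ccc1Oc1ccn2ncnc2c1` gives 2.65 nM, and compound 3 `Cc1cc(Nc2ncnc3cc(O)c(NC(=O)/C=C/[C@H]4CCCN4C)cc23)ccc1Oc1ccn2ccnc2c1` gives 4.55 nM. Compound 3 stands apart from compound 1 only: the series shows a 2.4-fold higher number from compound 1 to compound 3 (0.38 log units; beyond the scatter), alongside a 1.7-fold higher number from compound 2 to compound 3 (0.23 log units; within the scatter) and a 1.4-fold higher number from compound 1 to compound 2 (0.14 log units; within the scatter).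

Compound 4 `Cc1cc(Nc2ncnc3cc(O)c(NC(=O)/C=C/[C@H]4CCCN4C)cc23)ccc1Oc1cnn2cnnc2c1` carries a group of 9 heavy atoms (5 carbon, 4 nitrogen; one five-membered aromatic ring with 3 hetero atoms, one six-membered aromatic ring with 2 hetero atoms) in place of a group of 9 heavy atoms (7 carbon, 2 nitrogen; one five-membered aromatic ring with 2 hetero atoms, one six-membered aromatic ring with 1 hetero atom), on an oxygen on an aromatic ring. All three measured steps bear on this change, since each exchanges the group at that same place. Among the compounds with values here, of the groups, the one in compound 3 holds the fewest nitrogens and the one in compound 4 the most. So far, the compounds with more nitrogen in this group give numbers no higher than compound 3, but three compounds are a thin basis, and none has a group like the one entering here. A small move towards lower numbers is therefore expected, with nothing beyond the scatter: the estimated step is a 1.4-fold lower number from compound 3 to compound 4 (0.15 log units; within the scatter).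

The estimate for compound 4 is 3.2 nM, with an expected range of 1.2 nM to 8.5 nM.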

Compound 4, half-maximal inhibitory concentration: 28.3 nM
Compound 4: middle estimate off by 8.8-fold (0.95 log units), on the low side, outside the stated range (above it).
By their numbers in this assay, from the lowest: compounds 1, 2 and 3 (each within the scatter of the next, the first and the last beyond it); then compound 4.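

The group on the oxygen is not freely exchangeable in this assay: the group with 5 carbon, 4 nitrogen atoms gives a 6.2-fold higher number from compound 3 to compound 4 (0.79 log units; beyond the scatter) and also an 11-fold higher number from compound 2 to compound 4 (1.03 log units; beyond the scatter) as well as a 15-fold higher number from compound 1 to compound 4 (1.17 log units; beyond the scatter) in this series. The six-membered aromatic ring with 2 hetero atoms in compound 1 and the five-membered aromatic ring with 3 hetero atoms in compound 2 each stay at low numbers on their own, whereas compound 4, which combines both, does not, so the nitrogen count does not scale smoothly with the read-out. No measured property accompanies these numbers to account for the rise.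

As far as these compounds go, whether the rise follows the fourth nitrogen or its particular arrangement in the two rings remains open. Also open, from the compounds shown here alone, is how a single pyridine ring or a plain phenyl ring would behave on this oxygen.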